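Swapping Nitro for Chloro on a Shared Core

The source may report more compounds than this note shows. Statements on the series, on what has been measured and on what is new or still open speak of the compounds shown alone.

Compound 1, `N/C(=N/NC(CC(=O)c1ccc(-n2ccnc2)cc1)c1cccc([N+](=O)[O-])c1)c1ccccn1`: 28700 nM
Compound 2, `N/C(=N/NC(CC(=O)c1ccc(-n2ccnc2)cc1)c1ccc([N+](=O)[O-])cc1)c1ccccn1`: 23100 nM

In an ADME assay on Vero cells (Chlorocebus sabaeus) for cytotoxicity, read by MTT assay, with a stated time of 72 h (a higher number here means that more compound is tolerated, a lower number that less compound is tolerated), compound 1 gives 28700 nM and compound 2 gives 23100 nM. Compound 2 stands at the lower of these two numbers, but the step of a 1.2-fold lower number from compound 1 to compound 2 (0.09 log units; within the scatter) lies within the scatter, so the two compounds are not told apart. Compound 3, `N/C(=N/NC(CC(=O)c1ccc(-n2ccnc2)cc1)c1ccc(Cl)cc1)c1ccccn1`, differs from compound 2 by chloro in place of nitro on an aromatic carbon. For the measured compounds named here, no measured step bears on this exchange; the only measured step, a 1.2-fold lower number from compound 1 to compound 2 (0.09 log units; within the scatter), concerns where the nitro sits, not its replacement. Compound 3 is therefore expected to show no step beyond the scatter, a 1.0-fold lower number from compound 2 to compound 3 (0.00 log units; within the scatter). The estimate for compound 3 is 23000 nM, between 11000 nM and 48000 nM.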

Compound 3, half-maximal cytotoxic concentration: 78800 nM
For compound 3 the middle estimate is 3.4-fold (0.53 log units) below the measured one; the whole stated range lies below it.
By their numbers in this assay, from the lowest: compounds 2 and 1 (each within the scatter of the next); then compound 3.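

The two nitro compounds could not be told apart in this assay, but replacing the nitro itself does register: chloro on this aromatic carbon gives a 3.4-fold higher number from compound 2 to compound 3 (0.53 log units; beyond the scatter), so more compound is tolerated. Compound 3 also stands clear of the other nitro compound, with a 2.7-fold higher number from compound 1 to compound 3 (0.44 log units; beyond the scatter) across a change of both group and place. Nothing available explains this gain. From the compounds shown here alone, whether fluoro, a methyl group or an amine on the same carbon would also raise the number remains open. So does how chloro would read at the place where compound 1 carries its nitro.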